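Compound 3 to compound 4: loss of 1-phenylethyl

This account rests on a few compounds, and the source may have more. Where it says the series, first, only, none or still open, it means among the compounds named here.

Measured in a functional assay on MCF7 cells (Homo sapiens) for antiproliferative activity, read by MTT assay, with a stated time of 24 h; a lower number here means a stronger inhibitor, a higher number a weaker inhibitor:
- compound 1 `CCCCc1oc2ccccc2c1C(=O)c1ccc(OCC(=O)NC(C)C)cc1`: > 50000 nM (a limit)
- compound 2 `CCCCc1oc2ccccc2c1C(=O)c1ccc(OCC(=O)N2CCCCC2)cc1`: > 50000 nM (a limit)
- compound 3 `CCCCc1oc2ccccc2c1C(=O)c1ccc(OCC(=O)N[C@@H](C)c2ccccc2)cc1`: 17900 nM

Compound 3 is the only one of the three with an actual number. Compound 1 and compound 2 both stand at the limit of > 50000 nM in this assay, at which 2 of the 3 values shown sit.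

Compound 4 `CCCCc1oc2ccccc2c1C(=O)c1ccc(OCCCC(=O)N2CCCC2)cc1` carries 2-((pyrrolidin-1-yl)carbonyl)ethyl in place of (1-phenylethyl)carbamoyl on a saturated chain carbon bound to an oxygen on an aromatic ring.

Among the compounds with values here, the steps that bear on this are an at least 2.7-fold lower number from compound 1 to compound 3 (0.44 log units; beyond the scatter) and an at least 2.7-fold lower number from compound 2 to compound 3 (0.44 log units; beyond the scatter). Both reach compound 3 by introducing 1-phenylethyl, which compound 4 lacks, so a weaker result is expected in this assay, quite possibly at the limit. The expected step is a 2.8-fold higher number from compound 3 to compound 4 (0.45 log units; beyond the scatter).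

For compound 4 the estimate is 50000 nM, with an expected range of 20000 nM to 100000 nM.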

Compound 4, half-maximal inhibitory concentration: 23500 nM
Beside the measured number, compound 4's estimate is 2.1-fold (0.33 log units) above it; measured number inside the range.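

In this assay, a measurable value does not depend on the 1-phenylethyl group: a 1.3-fold higher number from compound 3 to compound 4 (0.12 log units; within the scatter), so 2-((pyrrolidin-1-yl)carbonyl)ethyl, which has no amide hydrogen and no stereocentre, reads level with (1-phenylethyl)carbamoyl at this carbon. The two other amides read differently, with an at least 2.1-fold lower number from compound 2 to compound 4 (0.32 log units; beyond the scatter) and an at least 2.1-fold lower number from compound 1 to compound 4 (0.32 log units; beyond the scatter). Both steps start from a limit, not a number: the limit of > 50000 nM in this assay, at which 2 of the 4 values shown sit.

Going by these compounds, compound 4 changes chain and amine together, so the contribution of each stays open. Also open, on these data alone, is how a morpholine amide or a free carboxylic acid on this longer chain would read.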